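Swapping the Alkenyl Group on a Cell-Growth Inhibitor Series

The source may report more compounds than this note shows. Statements on the series, on what has been measured and on what is new or still open speak of the compounds shown alone.

Compound 1 `COc1cccc(Nc2nc(Oc3cccc(NC(=O)C=C(C)C)c3)c3sccc3n2)c1`: 27700 nM
Compound 2 `CC/C=C/C(=O)Nc1cccc(Oc2nc(Nc3cccc(OC)c3)nc3ccsc23)c1`: 19600 nM
Compound 3 `CC(C)=CC(=O)Nc1cccc(Oc2nc(Nc3cccc(C#N)c3)nc3ccsc23)c1`: 16900 nM

All three were tested in a functional assay on A549 cells (Homo sapiens) for inhibition, read by MTT assay, with a stated time of 72 h; a lower number here means a stronger inhibitor, a higher number a weaker inhibitor. Their numbers lie within the usual scatter of one another, so none of compound 1, compound 2 or compound 3 can be called the stronger inhibitor. Compound 4 `CC/C=C/C(=O)Nc1cccc(Oc2nc(Nc3cccc(C#N)c3)nc3ccsc23)c1` is not yet measured. It differs from compound 3 by but-1-en-1-yl in place of 2-methylprop-1-en-1-yl on a carbonyl carbon. The same change was made once before, from compound 1 to compound 2 (but-1-en-1-yl in place of 2-methylprop-1-en-1-yl on a carbonyl carbon), where it gave a 1.4-fold lower number from compound 1 to compound 2 (0.15 log units; within the scatter). The two cores carrying the change differ by cyano in place of methoxy on an aromatic carbon, and the change sits at the same place in both; that core difference gave a 1.6-fold lower number from compound 1 to compound 3 (0.21 log units; within the scatter). Because the earlier step of a 1.4-fold lower number from compound 1 to compound 2 (0.15 log units; within the scatter) stayed within the scatter, the expected step for compound 4 is a 1.3-fold lower number from compound 3 to compound 4 (0.11 log units; within the scatter). The estimate for compound 4 in this assay is 13000 nM, most likely between 6000 nM and 28000 nM.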

Compound 4, half-maximal inhibitory concentration: 14900 nM
Compound 4: the middle estimate sits 1.1-fold (0.06 log units) below what was measured, within the range that was stated.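

Putting but-1-en-1-yl in place of 2-methylprop-1-en-1-yl in this assay gives a 1.1-fold lower number from compound 3 to compound 4 (0.05 log units; within the scatter), and putting cyano in place of methoxy gives a 1.3-fold lower number from compound 2 to compound 4 (0.12 log units; within the scatter). The but-1-en-1-yl swap reads alike on both cores: the same change on two cores in this assay, a 1.4-fold lower number (0.15 log units; within the scatter) from compound 1 to compound 2 and a 1.1-fold lower number (0.05 log units; within the scatter) from compound 3 to compound 4, 1.2-fold (0.10 log units) apart, within the scatter of two such steps. For the compounds shown here, the cyano swap also reads alike, yet every one of these steps lies within the scatter, so this shows only that neither change moves the number much on these cores, not that a real effect travels from one core to another: the same change on two cores in this assay, a 1.6-fold lower number (0.21 log units; within the scatter) from compound 1 to compound 3 and a 1.3-fold lower number (0.12 log units; within the scatter) from compound 2 to compound 4, 1.2-fold (0.10 log units) apart, within the scatter of two such steps.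

The compounds shown leave open whether a longer chain or an amine on the carbonyl carbon would give a step beyond the scatter. The same question stands for a carboxylic acid in place of cyano.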